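The compounds below may be only part of what the source reports. "The series", "measured", "known", "first", "only" and "open" are said of these compounds alone.

Three compounds share one core and differ only in the group on the five-membered ring. Compound 1 `CNc1nc2c(Cl)c(Cl)ccc2n1COCCO` carries a methylamino group there. In a functional assay on KB cells (Homo sapiens) for inhibition (a lower number here means a stronger inhibitor, a higher number a weaker inhibitor), compound 1 gives > 100000 nM, which is a limit of the assay rather than a number. Compound 2 `OCCOCn1cnc2c(Cl)c(Cl)ccc21` has a hydrogen in that place, and in this assay compound 2 gives > 100000 nM, again a limit. Compound 3 `OCCOCn1c(S)nc2c(Cl)c(Cl)ccc21` carries a sulfanyl group there, and in this assay compound 3 gives > 100000 nM, also a limit. Because every value sits at the limit of > 100000 nM in this assay, at which 3 of the 3 values shown sit, the steps between the three cannot be read: a step that the two limits leave unreadable from compound 1 to compound 2, a step that the two limits leave unreadable from compound 1 to compound 3 and a step that the two limits leave unreadable from compound 2 to compound 3. Compound 3 thus stands where the others stand, at the limit, with no number of its own.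

Compound 4 `OCCOCn1c(Br)nc2c(Cl)c(Cl)ccc21` differs from compound 3 in one place: bromo in place of sulfanyl on an aromatic carbon. The measured steps that touch this position, a step that the two limits leave unreadable from compound 1 to compound 3 and a step that the two limits leave unreadable from compound 2 to compound 3, gave no readable size, and none of the groups tried there has brought the inhibition below the limit. No step beyond the scatter is therefore expected, and the estimate corresponds to a number no higher from compound 3 to compound 4 (the limit leaves the size open). Compound 4 is expected to give about 100000 nM in this assay, within a range of 30000 nM to 300000 nM, most likely reported once more only as a limit.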

Compound 4, half-maximal inhibitory concentration: > 100000 nM
Compound 4 ended at the assay's limit (the forecaster's own chance of this, stated with the estimate: 85%); the middle value lies on the limit itself.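

No new step can be read from compound 4 to compound 1, compound 2 or compound 3, because all four values are limits and not numbers: the limit of > 100000 nM in this assay, at which 4 of the 4 values shown sit.

The compounds shown leave open whether any group in this place on the shared core gives a readable inhibition in this assay, and how these four compounds truly rank.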